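The compounds below may be only part of what the source reports. "The series", "measured", "known", "first", "only" and "open" are said of these compounds alone.

Of the compounds shown here, two in this set have already been tested in a functional assay on HCC78 cells (Homo sapiens) for antiproliferative activity, read by MTT assay, with a stated time of 48 h; a lower number here means a stronger inhibitor, a higher number a weaker inhibitor. Compound 1 `CC(Oc1cccnc1Nc1cnn(C)c1)c1cccc(C(=O)NCc2ccc(OC(F)(F)F)cc2)c1` gives 73900 nM in this assay. Compound 2 `Cc1ccc(CNC(=O)c2cccc(C(C)Oc3cccnc3Nc3ncccn3)c2)cc1` has no number in this assay, only a limit, > 100000 nM, and it sits at the limit of > 100000 nM in this assay, at which 1 of the 2 values shown sits. Compound 3 `Cc1ccc(CNC(=O)c2cccc(C(C)Oc3cccnc3Nc3nccs3)c2)cc1` is the next compound to be measured. It differs from compound 2 in a single place: 1,3-thiazol-2-yl in place of pyrimidin-2-yl on a nitrogen on an aromatic ring. Going by the values given here, no step between two measured compounds is available here, so the size of this change cannot be read off anything already measured. The expected step from compound 2 to compound 3 in this assay is an at least 1.2-fold lower number from compound 2 to compound 3 (0.09 log units; that floor lies within the scatter), which amounts to no movement beyond the usual scatter, in either direction. Compound 3 is therefore estimated at 80000 nM, with an expected range from 25000 nM to 250000 nM, and with a real chance that this assay again reports only a limit.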

Compound 3, half-maximal inhibitory concentration: 27100 nM
Beside the measured number, compound 3's estimate is 3.0-fold (0.47 log units) above it, within the range that was stated.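

Compound 2 has only a limit in this assay, not a number: the limit of > 100000 nM in this assay, at which 1 of the 3 values shown sits.

Placing 1,3-thiazol-2-yl in place of pyrimidin-2-yl on a nitrogen on an aromatic ring gives an at least 3.6-fold lower number from compound 2 to compound 3 (0.56 log units; beyond the scatter). Going by these compounds alone, this is the first single-place comparison in the set, and it shows that the group at this position can shift the result beyond the usual scatter, even though this ring is smaller by one atom and both rings carry two hetero atoms. The step alone gives no cause for the shift.

The compounds shown leave open whether the sulfur or the five-membered ring matters more, a question that 1,3-oxazol-2-yl, with oxygen in place of sulfur, or a six-membered pyridin-2-yl could help to answer. They also leave open whether 1,3-thiazol-2-yl would give a similar step alongside a different amide part.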